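Swapping a Ring Substituent on a Cytotoxic Core

The source may hold more compounds than are shown below. What is called first, only, known or untested is meant among the compounds shown, and "the series" means these compounds.

Compound 1 `O=C1C(=Cc2ccc(Cl)cc2)C(=O)N(c2ccc(Cl)cc2)N1c1ccc(Cl)cc1`: 17300 nM
Compound 2 `COc1cc(C=C2C(=O)N(c3ccc(Cl)cc3)N(c3ccc(Cl)cc3)C2=O)cc(OC)c1OC`: 10100 nM

In a functional assay on ECa-109 cells (Homo sapiens) for cytotoxicity, read by MTT assay, with a stated time of 72 h (a higher number here means a weaker inhibitor, a lower number a stronger inhibitor), compound 1 gives 17300 nM, the highest of the two numbers shown, and compound 2 gives 10100 nM; the gap between them lies within the scatter, so neither can be called the stronger. Compound 3 `COc1cccc(C=C2C(=O)N(c3ccc(Cl)cc3)N(c3ccc(Cl)cc3)C2=O)c1` is not yet measured. It differs from compound 1 by 3-methoxyphenyl in place of 4-chlorophenyl on a double-bonded chain carbon bound to a double-bonded ring carbon. Among the compounds with values here, no measured pair shows this change, so no step beyond the scatter is expected in either direction. Compound 3 is expected to give about 13000 nM, between 5000 nM and 35000 nM. The expected step of a 1.3-fold lower number from compound 1 to compound 3 (0.12 log units; within the scatter) is estimated to stay within the scatter.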

Compound 3, half-maximal inhibitory concentration: 29000 nM
Beside the measured number, compound 3's estimate is 2.2-fold (0.35 log units) below it; measured number inside the range.
By their numbers in this assay, from the lowest: compounds 2, 1 and 3 (each within the scatter of the next, the first and the last beyond it).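

In this assay, within the data shown here, 3-methoxyphenyl in place of 4-chlorophenyl on a double-bonded chain carbon bound to a double-bonded ring carbon gives a 1.7-fold higher number from compound 1 to compound 3 (0.22 log units; within the scatter), the first direct reading of a single change at this place. This swap therefore cannot be told apart from the scatter, and neither compound 1 nor compound 3 can be called the stronger. No measurement here offers an explanation for this result. From the compounds shown here alone, whether a phenyl ring carrying an amine or a carboxylic acid at this place would give a step beyond the scatter stays open.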